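Two fluorinated sulfonyl quinolines and a positional swap

A few compounds are considered here, and "the series" means these few. Any claim that something is new, unique, unknown or untested is made for them only; others in the source may bear on it.

Measured compounds:
compound 1 `O=S(=O)(c1ccc(F)cc1)c1cnc2cc(F)ccc2c1-c1cccc(F)c1`, 0.95 mL/min
compound 2 `O=S(=O)(c1cccc(F)c1)c1cnc2cc(F)ccc2c1-c1ccc(Cl)cc1`, 0.98 mL/min

In an ADME assay on microsomes from liver (Homo sapiens) for metabolic stability, tested at 2.5 uM (on this read-out lower numbers stand for slow clearance and higher numbers for fast clearance), compound 1 gives 0.95 mL/min. Compound 2 gives 0.98 mL/min, nominally the larger of the two numbers, yet its gap to compound 1 lies within the scatter, so the two are indistinguishable. Compound 3 `O=S(=O)(c1ccc(F)cc1)c1cnc2cc(F)ccc2c1-c1ccc(Cl)cc1` is not yet measured. It differs from compound 2 by 4-fluorophenyl in place of 3-fluorophenyl on a sulfonyl sulfur. Among the compounds with values here, no step between measured compounds informs this change, so a step from compound 2 to compound 3 of a 1.0-fold higher number from compound 2 to compound 3 (0.01 log units; within the scatter) is expected, that is none beyond the scatter. Compound 3 is estimated at 1 mL/min, between 0.55 mL/min and 1.8 mL/min.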

Compound 3, intrinsic clearance in a liver preparation (reported as CLH), per the amount of preparation that the assay uses: 1.23 mL/min
Estimate against measurement, compound 3: 1.2-fold (0.09 log units) below; the range from low to high includes it.
By their numbers in this assay, from the lowest: compounds 1, 2 and 3 (each within the scatter of the next).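

In this assay, the step of a 1.3-fold higher number from compound 2 to compound 3 (0.10 log units; within the scatter) shows that 4-fluorophenyl in place of 3-fluorophenyl on a sulfonyl sulfur leaves the read-out indistinguishable. The second change, 4-chlorophenyl in place of 3-fluorophenyl on an aromatic carbon, gives a 1.3-fold higher number from compound 1 to compound 3 (0.11 log units; within the scatter) and likewise stays within the scatter. Nothing available here accounts for either result. As far as these compounds go, all three compounds carry a fluorophenyl group on the sulfonyl sulfur, so it remains open whether an amine or a carboxylic acid at that place would shift clearance beyond the scatter.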